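Swapping 3-bromophenyl for 4-chlorophenyl on the shared core

A few compounds are considered here, and "the series" means these few. Any claim that something is new, unique, unknown or untested is made for them only; others in the source may bear on it.

Measured so far in a functional assay on SGC-7901 cells (Homo sapiens) for inhibition, read by MTT assay, with a stated time of 24 h; a lower number here means a stronger inhibitor, a higher number a weaker inhibitor:
compound 1 `CC1(C)[C@H]2CC[C@]1(C)N(Cc1cn(-c3cccc(F)c3)nn1)C(=O)C2`: 530 nM
compound 2 `CC1(C)[C@H]2CC[C@]1(C)N(Cc1cn(-c3ccc(Br)cc3)nn1)C(=O)C2`: 450 nM
compound 3 `CC1(C)[C@H]2CC[C@]1(C)N(Cc1cn(-c3cccc(Br)c3)nn1)C(=O)C2`: 120 nM

Compound 3, at 120 nM, has the lowest number of the three, and its gaps to both others lie beyond the scatter. The unmeasured compound 4 `CC1(C)[C@H]2CC[C@]1(C)N(Cc1cn(-c3ccc(Cl)cc3)nn1)C(=O)C2` keeps the shared core but carries 4-chlorophenyl in place of 3-bromophenyl on an aromatic nitrogen. Within the data shown here, both the halogen and its place on the phenyl ring change, and no measured compound carries chloro, so no measured step covers this change directly.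

The closest guide is a 3.8-fold lower number from compound 2 to compound 3 (0.57 log units; beyond the scatter), since compound 2 carries 4-bromophenyl, and the change at hand runs largely against that step. The halogen itself also mattered in a 4.4-fold lower number from compound 1 to compound 3 (0.65 log units; beyond the scatter). By contrast, a 1.2-fold lower number from compound 1 to compound 2 (0.07 log units; within the scatter) separates the other two values by no more than the scatter, and only compound 3 stands apart. A move back towards those two values is therefore expected in this assay, a modest step to a higher number. The expected step is a 4.0-fold higher number from compound 3 to compound 4 (0.60 log units; beyond the scatter). For compound 4 the estimated value is 480 nM, with an expected range from 200 nM to 1100 nM.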

Compound 4, half-maximal inhibitory concentration: 410 nM
For compound 4 the middle estimate is 1.2-fold (0.07 log units) above the measured one, within the range that was stated.
By their numbers in this assay, from the lowest: compound 3; then compounds 4, 2 and 1 (each within the scatter of the next).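

In this assay, the change from 3-bromophenyl to 4-chlorophenyl gives a 3.4-fold higher number from compound 3 to compound 4 (0.53 log units; beyond the scatter), while exchanging the halogen between 4-bromophenyl and 4-chlorophenyl gives only a 1.1-fold lower number from compound 2 to compound 4 (0.04 log units; within the scatter), and the change from 3-fluorophenyl to 4-chlorophenyl gives a 1.3-fold lower number from compound 1 to compound 4 (0.11 log units; within the scatter).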